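The source may hold more compounds than are shown below. What is called first, only, known or untested is meant among the compounds shown, and "the series" means these compounds.

Working notes on the series. The shared core is carried by compound 1 `O=C(O)CCc1ccncc1-c1ccc2ccccc2c1`, compound 2 `CNC(=O)COc1ccncc1-c1ccc2ccccc2c1` and compound 3 `O=C(/C=C/c1ccncc1-c1ccc2ccccc2c1)NC1CC1`, which differ only in the substituent on the aromatic carbon opposite the ring nitrogen. In a functional assay on HCT-116 cells (Homo sapiens) for inhibition, read by MTT assay, with a stated time of 72 h (a higher number here means a weaker inhibitor of growth, a lower number a stronger inhibitor of growth), compound 1 reaches only a limit, > 30000 nM, not a number. For compound 2 this assay gives "not determined" (no result reported), so compound 2 stands without a number of its own. Of the two results shown, one is absent, and the other, that of compound 1, is a limit (the limit of > 30000 nM in this assay, at which 1 of the 2 values shown sits). The step to compound 3 brings (2-(cyclopropylcarbamoyl)ethenyl in place of (methylcarbamoyl)methoxy on an aromatic carbon). Among the compounds with values here, with no measured step in this assay to lean on, no step beyond the scatter is expected in either direction, and the weak growth inhibition seen for compound 1 is the only anchor. Compound 3 is expected to give around 20000 nM in this assay, within a range of 5000 nM to 40000 nM.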

Compound 3, concentration for 50% growth inhibition: 6180 nM
Compound 3: the middle estimate sits 3.2-fold (0.51 log units) above what was measured; the range from low to high includes it.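

Compound 3 gives 6180 nM in this assay, the only number among the compounds shown, so a substituent on the aromatic carbon opposite the ring nitrogen can go with measurable growth inhibition in the shared core. Placing 2-(cyclopropylcarbamoyl)ethenyl there instead of 2-carboxyethyl gives an at least 4.8-fold lower number from compound 1 to compound 3 (0.68 log units; beyond the scatter). The true size of that step stays open because compound 1 stands at a limit and not at a number: the limit of > 30000 nM in this assay, at which 1 of the 3 values shown sits.

The step involving compound 2 cannot be read, so the (methylcarbamoyl)methoxy group gives no comparison. Open too, going by these compounds, is which part of the change carries the step, the loss of the carboxylic acid, the ethenyl double bond or the cyclopropyl amide, and a saturated 2-(cyclopropylcarbamoyl)ethyl chain or a simple amine on this carbon would bear on that.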